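This account rests on a few compounds, and the source may have more. Where it says the series, first, only, none or still open, it means among the compounds named here.

Measured so far in a functional assay on U-87MG ATCC cells for antiproliferative activity against U-87 MG (Homo sapiens), read by MTT assay, with a stated time of 48 h; on this read-out lower numbers stand for stronger inhibition and higher numbers for weaker inhibition:
compound 1, `Cc1nc(-c2ccccc2)sc1C(=O)CSc1nc(-c2ccc(Cl)c(Cl)c2)c(C#N)c(=O)[nH]1`, gives 65000 nM;
compound 2, `Cc1nc(-c2ccccc2)sc1C(=O)CSc1nc(-c2ccccc2)c(C#N)c(=O)[nH]1`, gives 56600 nM;
compound 3, `COc1ccc(-c2nc(C)c(C(=O)CSc3nc(-c4ccc(Cl)c(Cl)c4)c(C#N)c(=O)[nH]3)s2)cc1`, gives 68500 nM.

All three numbers sit close together. Compound 2 differs from compound 1 by phenyl in place of 3,4-dichlorophenyl on an aromatic carbon, and that change made a 1.1-fold lower number from compound 1 to compound 2 (0.06 log units; within the scatter). Compound 3 differs from compound 1 by methoxy in place of hydrogen on an aromatic carbon, which made a 1.1-fold higher number from compound 1 to compound 3 (0.02 log units; within the scatter). Compound 3 therefore stands within the scatter of both earlier compounds.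

Compound 4, `COc1ccc(-c2nc(C)c(C(=O)CSc3nc(-c4ccccc4)c(C#N)c(=O)[nH]3)s2)cc1`, has not yet been measured. It differs from compound 3 by phenyl in place of 3,4-dichlorophenyl on an aromatic carbon, the same change that turns compound 1 into compound 2, here made on the core of compound 3, whose difference from the core of compound 1 is given by methoxy in place of hydrogen on an aromatic carbon. Since the surroundings of the place are the same in both pairs, the expectation rests on the earlier step: because a 1.1-fold lower number from compound 1 to compound 2 (0.06 log units; within the scatter) lay within the scatter, the step from compound 3 to compound 4 is expected to be a 1.1-fold lower number from compound 3 to compound 4 (0.06 log units; within the scatter). Compound 4 is thus estimated at 60000 nM, with a likely range from 35000 nM to 105000 nM.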

Compound 4, half-maximal inhibitory concentration: 57300 nM
Estimate against measurement, compound 4: 1.0-fold (0.02 log units) above; low and high end bracket the measured number.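

In this assay, phenyl in place of 3,4-dichlorophenyl gave a 1.2-fold lower number from compound 3 to compound 4 (0.08 log units; within the scatter), and the change behaved no differently on the two cores: the same change on two cores in this assay, a 1.1-fold lower number (0.06 log units; within the scatter) from compound 1 to compound 2 and a 1.2-fold lower number (0.08 log units; within the scatter) from compound 3 to compound 4, 1.0-fold (0.02 log units) apart, within the scatter of two such steps. Methoxy in place of hydrogen gave a 1.0-fold higher number from compound 2 to compound 4 (0.01 log units; within the scatter), and it too behaved no differently on the two cores: the same change on two cores in this assay, a 1.1-fold higher number (0.02 log units; within the scatter) from compound 1 to compound 3 and a 1.0-fold higher number (0.01 log units; within the scatter) from compound 2 to compound 4, 1.0-fold (0.02 log units) apart, within the scatter of two such steps. Going by these compounds alone, all of these steps lie within the scatter, so the agreement shows only that neither change moved the number on either core, and it does not show that a step of measurable size would carry over from one core to another.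

The compounds shown leave open whether another group at the place of the phenyl, such as an amine or a carboxylic acid, would move the number beyond the scatter. They also leave open whether a longer chain in place of the methoxy would do so, and whether any such step would then repeat on a second core.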